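A few compounds are considered here, and "the series" means these few. Any claim that something is new, unique, unknown or untested is made for them only; others in the source may bear on it.

Compound 1, `N#CC1=C(N)Oc2c(c3nc4ccccc4nc3c3ccccc23)C12C(=O)N(Cc1cnnn1-c1cccc(Br)c1)c1ccccc12`: in a functional assay on MCF7 cells (Homo sapiens) for antiproliferative activity, read by MTT assay, with a stated time of 48 h (a lower number here means a stronger inhibitor, a higher number a weaker inhibitor), compound 1 gives > 50000 nM, a limit of the assay.
Compound 2, `N#CC1=C(N)Oc2c(c3nc4ccccc4nc3c3ccccc23)C12C(=O)N(Cc1cnnn1-c1ccc(N)cc1)c1ccccc12`: compound 2 gives > 50000 nM, again a limit.
Compound 3, `Cc1ccc(-n2nncc2CN2C(=O)C3(C(C#N)=C(N)Oc4c3c3nc5ccccc5nc3c3ccccc43)c3ccccc32)cc1C`: compound 3 gives > 50000 nM, again a limit.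

None of the three values is a measured number; the limit of > 50000 nM in this assay, at which 3 of the 3 values shown sit, records that all three sit at the limit. Compound 1 therefore holds only a limit in this assay, and its place among the values shown cannot be fixed. Compound 4, `Cc1ccc(-n2nncc2CN2C(=O)C3(C(C#N)=C(N)Oc4c3c3nc5ccccc5nc3c3ccccc43)c3ccccc32)c(C)c1`, differs from compound 1 by 2,4-dimethylphenyl in place of 3-bromophenyl on an aromatic nitrogen. The nearest measured step is a step that the two limits leave unreadable from compound 1 to compound 3, which the two limits leave unreadable, and a step that the two limits leave unreadable from compound 1 to compound 2 and a step that the two limits leave unreadable from compound 2 to compound 3 are unreadable in the same way. Going by the values given here, no step gives a size, so compound 4 is expected to stay at the limit, with a step that the limit leaves unreadable from compound 1 to compound 4 expected to show no readable change. Compound 4 is expected near 60000 nM in this assay, within 25000 nM to 150000 nM.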

Compound 4, half-maximal inhibitory concentration: > 50000 nM
Compound 4: only a limit was reported; the forecaster's own chance of this, stated with the estimate: 85%; the middle value does not contradict the limit.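

Compound 4, like compounds 1, 2 and 3, holds only a limit, so no step from it to those three can be read: the limit of > 50000 nM in this assay, at which 4 of the 4 values shown sit.

The compounds shown leave open whether the group on the aromatic nitrogen changes the result in this assay at all.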